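A few compounds are considered here, and "the series" means these few. Any claim that something is new, unique, unknown or untested is made for them only; others in the source may bear on it.

Among the measured compounds shown here, compound 2 `CC(C)C[C@@H]1C(=O)N[C@H](C2Cc3ccccc3C2)C(=O)N1[C@@H](C(=O)NC(C)C)c1ccc(-c2ccccn2)s1` stands at the lower of the two numbers so far in an assay on isolated protein for binding affinity to Oxytocin receptor (Homo sapiens) (a lower number here means a stronger inhibitor, a higher number a weaker inhibitor), where compound 2 gives 2.51 nM. For the measured compounds named here, compound 1 `CNC(=O)c1ccc([C@H](C(=O)NC(C)C)N2C(=O)[C@@H](C3Cc4ccccc4C3)NC(=O)[C@H]2CC(C)C)o1` gives 39.8 nM, and the single measured step, a 16-fold lower number from compound 1 to compound 2 (1.20 log units; beyond the scatter), was large. Compound 3 `CC(C)C[C@@H]1C(=O)N[C@H](C2Cc3ccccc3C2)C(=O)N1[C@@H](C(=O)NC(C)C)c1ccc(Br)s1` carries bromo in place of pyridin-2-yl on an aromatic carbon. Going by the values given here, no measured step touches this substituent alone; the one known step reshaped the whole aryl group, so it bears on the change only loosely. The step expected is a 2.8-fold higher number from compound 2 to compound 3 (0.45 log units; beyond the scatter), a modest loss. Compound 3 is estimated at 7 nM, within 2 nM to 25 nM.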

Compound 3, inhibition constant: 2 nM
Compound 3: the middle estimate sits 3.5-fold (0.54 log units) above what was measured, and the stated range covers the measured number.
By their numbers in this assay, from the lowest: compounds 3 and 2 (each within the scatter of the next); then compound 1.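

In this assay, bromo can stand in place of pyridin-2-yl on this aromatic carbon with no change beyond the scatter (a 1.3-fold lower number from compound 2 to compound 3 (0.10 log units; within the scatter)), so the outer six-membered aromatic ring is not needed for the low number. The 5-bromothiophen-2-yl group also keeps the large difference from the furan-bearing compound (a 20-fold lower number from compound 1 to compound 3 (1.30 log units; beyond the scatter)). No measured evidence bears on why this is so. The compounds shown leave open how an amine, a carboxylic acid or a longer chain on this aromatic carbon would read, and whether plain hydrogen there would hold the number.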